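Aryl groups on the sulfonamide nitrogen: working notes

The source may report more compounds than this note shows. Statements on the series, on what has been measured and on what is new or still open speak of the compounds shown alone.

- compound 1 `O=C1NCCN1c1ccc(S(=O)(=O)Nc2ccc(F)cc2)cc1` with 690 nM
- compound 2 `O=C1NCCN1c1ccc(S(=O)(=O)Nc2ccc(F)c(F)c2)cc1` with 620 nM
- compound 3 `O=C1NCCN1c1ccc(S(=O)(=O)Nc2ccc(Cl)cc2)cc1` with 170 nM

These values come from a functional assay on MCF7 cells (Homo sapiens) for antiproliferative activity, read by sulforhodamine B assay, with a stated time of 48 h (a lower number here means a stronger inhibitor, a higher number a weaker inhibitor), and compound 3 has the lowest of the three, with both of its steps beyond the scatter. Next is compound 4 `Cc1cccc(NS(=O)(=O)c2ccc(N3CCNC3=O)cc2)c1C` with 2,3-dimethylphenyl in place of 4-chlorophenyl on a sulfonamide nitrogen. The nearest evidence is a 4.1-fold lower number from compound 1 to compound 3 (0.61 log units; beyond the scatter) and a 3.6-fold lower number from compound 2 to compound 3 (0.56 log units; beyond the scatter) as both modest steps involve the leaving group. The other step, a 1.1-fold lower number from compound 1 to compound 2 (0.05 log units; within the scatter), stays within the scatter. For the measured compounds named here, no measured compound carries a methyl group, so the size remains uncertain. The expected change is a modest rise, estimated as a 2.5-fold higher number from compound 3 to compound 4 (0.39 log units; beyond the scatter) in this assay. For compound 4 the estimated value is 420 nM, with an expected range from 130 nM to 1400 nM.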

Compound 4, half-maximal inhibitory concentration: 230 nM
Beside the measured number, compound 4's estimate is 1.8-fold (0.26 log units) above it; the range from low to high includes it.
By their numbers in this assay, from the lowest: compounds 3 and 4 (each within the scatter of the next); then compounds 2 and 1 (each within the scatter of the next).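

In this assay the aryl group on the sulfonamide nitrogen needs no halogen to reach the low numbers of this set, with a 1.4-fold higher number from compound 3 to compound 4 (0.13 log units; within the scatter) on exchanging 4-chlorophenyl for 2,3-dimethylphenyl. The 2,3-dimethylphenyl group also stands apart from both fluorinated aryl groups, with a 2.7-fold lower number from compound 2 to compound 4 (0.43 log units; beyond the scatter) and a 3.0-fold lower number from compound 1 to compound 4 (0.48 log units; beyond the scatter) in the same direction as the steps to compound 3. Nothing measured here accounts for these steps.

Still open, from the compounds shown here alone, is how a single methyl group would compare with the two in compound 4. Also open, going by these compounds, is how an amine or a carboxylic acid on this aryl group would read in this assay.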